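Amide side-chain variation in the shared core series

The source may report more compounds than this note shows. Statements on the series, on what has been measured and on what is new or still open speak of the compounds shown alone.

Measured so far:
compound 1, `CCN(CC)CCNC(=O)c1ccc(C(CC)(CC)c2ccc(OCC(O)C(C)(C)C)c(C)c2)n1CC`: 76.8 nM
compound 2, `CCn1c(C(=O)NCC(=O)O)ccc1C(CC)(CC)c1ccc(C#CC(O)(CC)CC)c(C)c1`: 85.7 nM

In an assay on cells for binding affinity to vitamin D3 receptor (Homo sapiens), read by fluorescence polarization (on this read-out higher numbers stand for weaker inhibition and lower numbers for stronger inhibition), compound 1 gives 76.8 nM and compound 2 gives 85.7 nM; the two values lie within the scatter of each other, so no order between them is claimed. Compound 3, `CCn1c(C(=O)NCCCO)ccc1C(CC)(CC)c1ccc(C#CC(O)(CC)CC)c(C)c1`, has not yet been measured in this assay. It differs from compound 2 by 2-hydroxyethyl in place of carboxy on a saturated chain carbon bound to an amide-type nitrogen. Within the data shown here, no measured pair isolates this change, so no step size is known. For compound 3 the expectation in this assay is a step of a 1.1-fold higher number from compound 2 to compound 3 (0.02 log units; within the scatter), not beyond the scatter. Compound 3 is therefore estimated at 90 nM, with a range of 40 nM to 200 nM.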

Compound 3, half-maximal inhibitory concentration: 123 nM
Beside the measured number, compound 3's estimate is 1.4-fold (0.14 log units) below it; the measured number falls inside the stated range.
By their numbers in this assay, from the lowest: compounds 1, 2 and 3 (each within the scatter of the next).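

Exchanging (carboxymethyl)carbamoyl for (3-hydroxypropyl)carbamoyl gives a 1.4-fold higher number from compound 2 to compound 3 (0.16 log units; within the scatter) in this assay, the first step read at this place in the series. Carboxy on this chain is thus not needed for a value within the scatter of compound 2, and 2-hydroxyethyl serves there as well. No supporting evidence bears on this result.

Still open, as far as these compounds go, is whether an amine or a longer chain at this place would give a step beyond the scatter. Also open, from the compounds shown here alone, is whether the same exchange behaves alike on the core of compound 1.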